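The source may hold more compounds than are shown below. What is called first, only, known or untested is meant among the compounds shown, and "the series" means these compounds.

Compound 1 `COc1ccc(-c2cc(=O)c3c(O)c(OC)c(O[C@@H]4O[C@H](CO[C@@H]5O[C@@H](C)[C@H](O)[C@@H](OC(C)=O)[C@H]5O)[C@@H](O)[C@H](O)[C@H]4O)cc3o2)cc1` is a flavone glycoside in which the sugar chain carries an acetyl group. In a functional assay on HepG2 cells (Homo sapiens) for inhibition, in the presence of a further agent that is not named here (a lower number here means a stronger inhibitor, a higher number a weaker inhibitor), compound 1 gives 30600 nM. Two companions were measured alongside it. Compound 2 `COc1ccc(-c2cc(=O)c3c(O)c(OC)c(O[C@@H]4OC(CO[C@@H]5OC(C)[C@H](O)[C@H](O)C5OC(C)=O)[C@@H](O)[C@H](O)C4O)cc3o2)cc1`, which shares the same atoms and bonds but is drawn with fewer stereocentres assigned, gives in this assay 16400 nM. Compound 3 `COC1=C(O)C2=C(O)C=C(c3ccc(OC)cc3)OC2=CC1OC1OC(O)C(O)C(O)C1O`, a smaller glycoside without the acetylated second sugar, gives in this assay 17400 nM. Compound 1 thus carries the largest of the three numbers, yet its gaps to compound 3 and to compound 2 both fall within the usual scatter of repeated measurements, so the three results are not distinguished from one another.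

The step under consideration leads from compound 1 to compound 4 `COc1ccc(-c2cc(=O)c3c(O)c(OC)c(O[C@@H]4OC(CO[C@@H]5OC(C)[C@H](O)[C@H](OC(C)=O)C5O)[C@@H](O)[C@H](O)C4O)cc3o2)cc1`. The difference is confined to how stereocentres are drawn: the two compounds have the same atoms and bonds; at least one stereo element is drawn with a configuration in one of them and without one in the other: 5 of 10 stereo elements differ; a stereocentre at a saturated ring carbon is drawn R in compound 1 and without a configuration in compound 4; a stereocentre at a saturated ring carbon is drawn S in compound 1 and without a configuration in compound 4; a stereocentre at a saturated ring carbon is drawn R in compound 1 and S in compound 4; a stereocentre at a saturated ring carbon is drawn R in compound 1 and without a configuration in compound 4. No atom leaves and none enters. With the other two measured compounds already sitting within the scatter of compound 1, nothing here points to a change in potency beyond that scatter, and the step from compound 1 to compound 4 is expected to be a 1.3-fold lower number from compound 1 to compound 4 (0.11 log units; within the scatter). Compound 4 is therefore estimated to give 24000 nM in this assay, with a range from 10000 nM to 60000 nM.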

Compound 4, half-maximal inhibitory concentration: 10900 nM
Compound 4: the middle estimate sits 2.2-fold (0.34 log units) above what was measured; measured number inside the range.
By their numbers in this assay, from the lowest: compounds 4, 2, 3 and 1 (each within the scatter of the next, the first and the last beyond it).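

In this assay, among the compounds shown here, a 2.8-fold lower number from compound 1 to compound 4 (0.45 log units; beyond the scatter) is a modest step, yet it shows what the earlier compounds could not: with no atom leaving or entering, a difference in how the stereocentres at saturated ring carbons are drawn coincides with a gap beyond the scatter. Among compounds 1, 2 and 3, no gap of this kind had appeared, so this is the first sign that the result in this assay can differ between two compounds with the same atoms and bonds. The step cannot be credited to a single centre, because only one stereocentre is drawn with opposite configurations, while the other differences involve a configuration drawn in compound 1 and left undefined in compound 4, and the only evidence available is this: the fact that one of compounds 1 and 4 is drawn with a defined configuration and the other without, at the place where they differ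

Which of the 5 differing stereo elements accounts for the step remains open, as does whether compound 4 is a single stereoisomer. Also open, going by these compounds, is whether the acetyl group on the second sugar matters at all, since a propanoyl or a benzoyl group in its place would be needed to show how this assay responds to that ester.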